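Swapping Isopropyl for Cyclopentyl on a Weak Antiproliferative Lead

This account rests on a few compounds, and the source may have more. Where it says the series, first, only, none or still open, it means among the compounds named here.

Among the measured compounds shown here, compound 1 `CC(C)n1cnc2c(Nc3ccccc3)nc(NCOCc3ccc(C(=O)Nc4ccccc4N)cc3)nc21` stands lowest of the two numbers measured so far. In a functional assay on NCI-H460 cells (Homo sapiens) for antiproliferative activity, read by CCK-8 assay, with a stated time of 72 h, tested at 2 uM (on this read-out higher numbers stand for a stronger effect at the one concentration tested and lower numbers for a weaker effect), compound 1 gives 15%. Compound 2 `CC(C)n1cnc2c(Nc3ccccc3)nc(NCOCc3ccc(/C=C/C(=O)Nc4ccccc4N)cc3)nc21` differs from it only at the amide end, and in this assay compound 2 gives 41%; the step of a number 26 percentage points higher from compound 1 to compound 2 (beyond the scatter) is a modest gain that lies beyond the scatter.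

Compound 3 `Nc1ccccc1NC(=O)c1ccc(COCNc2nc(Nc3ccccc3)c3ncn(C4CCCC4)c3n2)cc1` has not yet been tested. It differs from compound 1 at a different spot: cyclopentyl in place of isopropyl on an aromatic nitrogen. For the measured compounds named here, no measured step touches this part of the molecule, so the one known step offers no direct guidance: it only shows that a change at the amide end can shift the read-out while the rest stays unchanged. With nothing to argue for a gain or a loss at the ring nitrogen, the expectation for compound 3 in this assay is a step of a number 3 percentage points higher from compound 1 to compound 3 (within the scatter) that stays within the scatter. Compound 3 is therefore estimated to give about 18%, with a likely range from 5% to 35%.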

Compound 3, a percentage reported as inhibition, at one concentration (the size of the read-out at that concentration, not a potency): 41.2%
For compound 3 the middle estimate is 23.2 percentage points below the measured one, and the stated range ends below it.
By their numbers in this assay, from the lowest: compound 1; then compounds 2 and 3 (each within the scatter of the next).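

At the aromatic nitrogen, in this assay, cyclopentyl in place of isopropyl gives a number 26.2 percentage points higher from compound 1 to compound 3 (beyond the scatter) and so counts as a modest gain. Among the compounds shown here, this shows that the read-out responds to this position as well as to the amide end, the only place where a change had been seen to matter so far: swapping a small open-chain group for a five-membered carbon ring, with the rest of compound 1 left unchanged, is enough to move it beyond the usual scatter. The result shows that the change raises the number, but nothing available bears on why it does so.

Going by these compounds, whether the gain depends on ring size or on the number of carbons remains open, and a cyclobutyl, a cyclohexyl or an open-chain n-pentyl group on the same nitrogen would help to separate these two possibilities. On these data alone, it is also open whether cyclopentyl and the 2-((2-aminophenyl)carbamoyl)ethenyl group, each tied to a higher number when placed on compound 1 alone, would add up when carried together in one molecule.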